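This account rests on a few compounds, and the source may have more. Where it says the series, first, only, none or still open, it means among the compounds named here.

Going by the values given here, in a functional assay on RAW264.7 cells (Mus musculus) for inhibition, with stated times of 2 h and 24 h (a higher number here means a weaker inhibitor, a lower number a stronger inhibitor), the compounds measured so far have given no number. Compound 1 `COc1ccc(/C=C2/c3cc(OC)cc(OC)c3[C@@H](c3ccccc3)[C@@H]2c2cc(OC)cc(OC)c2)cc1` gives > 200000 nM, which is a limit of the assay. Compound 2 `COc1cc(OC)cc([C@@H]2C(SCc3ccccc3)c3cc(OC)cc(OC)c3[C@H]2c2ccccc2)c1` gives > 200000 nM, again a limit. Compound 3 `COc1ccc([C@@H]2c3c(OC)cc(OC)cc3C(SCc3ccc(F)cc3)[C@H]2c2cc(OC)cc(OC)c2)cc1` gives > 200000 nM, also only a limit. Compound 3 therefore stands with the other two, at the limit of > 200000 nM in this assay, at which 3 of the 3 values shown sit. Compound 4 `COc1ccc([C@@H]2c3c(OC)cc(OC)cc3C(C(O)c3ccc(C)cc3)[C@H]2c2cc(OC)cc(OC)c2)cc1` differs from compound 3 by hydroxy(4-methylphenyl)methyl in place of (4-fluorobenzyl)sulfanyl on a saturated ring carbon. Among the compounds with values here, no measured step guides this change, so at most a modest move towards stronger inhibition is expected in this assay. The expected change is an at least 1.6-fold lower number from compound 3 to compound 4 (0.22 log units; that floor lies within the scatter). Compound 4 is estimated at 120000 nM, with an expected range of 30000 nM to 200000 nM, and it may again return only a limit.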

Compound 4, half-maximal inhibitory concentration: 26500 nM
Compound 4: middle estimate off by 4.5-fold (0.66 log units), on the high side; the whole stated range lies above it.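

In this assay, hydroxy(4-methylphenyl)methyl in place of (4-fluorobenzyl)sulfanyl on this saturated ring carbon gives an at least 7.5-fold lower number from compound 3 to compound 4 (0.87 log units; beyond the scatter). Compound 4 thus supplies the only actual number among the compounds shown, so a change at this position can bring the series within range of the assay. The other compounds gave only a limit: the limit of > 200000 nM in this assay, at which 3 of the 4 values shown sit.

The compounds shown leave open whether the hydroxy group, the 4-methylphenyl ring or the loss of sulfur accounts for the step. On these data alone, how an amine or a carboxylic acid on this ring carbon would read in this assay also remains open.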